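A few compounds are considered here, and "the series" means these few. Any claim that something is new, unique, unknown or untested is made for them only; others in the source may bear on it.

In a functional assay on MCF7 cells (Homo sapiens) for cytotoxicity, read by MTT assay, with a stated time of 24 h, tested at 0.64 ug/mL (a lower number here means a weaker effect, a higher number a stronger effect of the compound at the concentration tested), compound 1 `Cn1c(-c2ccc(NC(=O)CSc3nc4ccccc4s3)cc2)nc(-c2ccccc2)c1-c1ccccc1` gives 0.9%, and compound 2 `CN(C)/C=C/N1CCN(CC(=O)Nc2ccc(-c3nc(-c4ccccc4)c(-c4ccccc4)n3C)cc2)CC1` gives 1.2%. Of the two numbers compound 2 carries the top one, yet a number 0.3 percentage points higher from compound 1 to compound 2 (within the scatter) stays within the scatter, so the two compounds cannot be told apart. Compound 3 `COc1ccc(CN2CCN(CC(=O)Nc3ccc(-c4nc(-c5ccccc5)c(-c5ccccc5)n4C)cc3)CC2)cc1` differs from compound 2 by 4-methoxybenzyl in place of 2-(dimethylamino)ethenyl on an amine nitrogen in a ring. Among the measured compounds shown here, the only measured step, a number 0.3 percentage points higher from compound 1 to compound 2 (within the scatter), touches a different part of the molecule and did not move the read-out, so no step beyond the scatter is expected here, a number 0.3 percentage points higher from compound 2 to compound 3 (within the scatter). Compound 3 is therefore estimated at 1.5%, between 0% and 12%.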

Compound 3, a percentage reported as activity, at one concentration (the size of the read-out at that concentration, not a potency): 1%
Estimate against measurement, compound 3: 0.5 percentage points above, within the range that was stated.
By their numbers in this assay, from the lowest: compounds 1, 3 and 2 (each within the scatter of the next).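

At the amine nitrogen in the ring, 4-methoxybenzyl in place of 2-(dimethylamino)ethenyl brings in a larger group with a six-membered aromatic ring, and in this assay this gives a number 0.2 percentage points lower from compound 2 to compound 3 (within the scatter), so this position, too, leaves the read-out unmoved. Among the compounds shown here, the change at this ring nitrogen thus joins the change on the chain carbon in separating no compounds. Nothing available explains this result. From the compounds shown here alone, whether a carboxylic acid, a primary amine or a longer chain on this ring nitrogen would move the read-out beyond the scatter remains open.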